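Furan-triazolothiadiazine series: para substituent on the benzoyl ring

The source may hold more compounds than are shown below. What is called first, only, known or untested is meant among the compounds shown, and "the series" means these compounds.

Measured so far:
compound 1, `COc1cc(-c2nnc3n2NC(c2ccco2)C(C(=O)c2ccc(Br)cc2)S3)cc(OC)c1OC`, 36400 nM in a functional assay on PC-3 cells (Homo sapiens) for cytotoxicity, read by MTT assay, with a stated time of 48 h; on this read-out lower numbers stand for stronger inhibition and higher numbers for weaker inhibition
compound 2, `COc1cc(-c2nnc3n2NC(c2ccco2)C(C(=O)c2ccccc2)S3)cc(OC)c1OC`, 64300 nM in this assay

Compound 2 and compound 1 share the whole core and differ only at the para position of the benzoyl ring. The one measured step, a 1.8-fold higher number from compound 1 to compound 2 (0.25 log units; within the scatter), lies within the scatter, so compound 2 and compound 1 cannot be separated on the numbers shown; compound 2 is simply the member with the higher reading of the two.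

Compound 3, `COc1cc(-c2nnc3n2NC(c2ccco2)C(C(=O)c2ccc(O)cc2)S3)cc(OC)c1OC`, continues the same exercise at the same place: hydroxy in place of hydrogen on an aromatic carbon. For the measured compounds named here, the only measured step that bears on it is the one from compound 1 to compound 2, which exchanged one para substituent for another on this ring without moving the number beyond the scatter. With a single step of that kind to go on, no step beyond the scatter is expected in this assay from compound 2 to compound 3, though the lone precedent leaves the direction open. The expected step is a 1.3-fold lower number from compound 2 to compound 3 (0.11 log units; within the scatter). Compound 3 is therefore estimated at 50000 nM, with a range from 20000 nM to 130000 nM.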

Compound 3, half-maximal inhibitory concentration: 38300 nM
Estimate against measurement, compound 3: 1.3-fold (0.12 log units) above, within the range that was stated.
By their numbers in this assay, from the lowest: compounds 1, 3 and 2 (each within the scatter of the next).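

Hydroxy in place of hydrogen on the aromatic carbon gives a 1.7-fold lower number from compound 2 to compound 3 (0.23 log units; within the scatter) in this assay, so a group with a hydrogen-bond donor and acceptor at this position produces no step that can be read. The direct exchange of the two substituents, hydroxy in place of bromo, gives a 1.1-fold higher number from compound 1 to compound 3 (0.02 log units; within the scatter), and compound 1 and compound 3 cannot be separated on these numbers. For the compounds shown here, the single step available earlier now has two companions: all three pairs among hydrogen, bromo and hydroxy lie within the scatter, and none of these groups can be told from the others at this position in this assay. No measurement on these compounds offers an explanation for how closely the readings sit.

On these data alone, whether an amine, a carboxylic acid or a longer chain such as butoxy at this place on the benzoyl ring would give a step beyond the scatter remains open. Also open, as far as these compounds go, is whether hydrogen, bromo and hydroxy would still read alike on a core other than the one shared here.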